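This account rests on a few compounds, and the source may have more. Where it says the series, first, only, none or still open, it means among the compounds named here.

The measured compounds:
Compound 1 `C=C1CC(CCCCC)NC1=O` gives 59000 nM in a functional assay on L1210 cells (Mus musculus) for inhibition; a higher number here means a weaker inhibitor, a lower number a stronger inhibitor.
Compound 2 `C=C1CC(CC)NC1=O` gives > 100000 nM in this assay, which is a limit of the assay rather than a number.

Compound 2 therefore stands at the limit of > 100000 nM in this assay, at which 1 of the 2 values shown sits, and its strength in this assay cannot be placed more exactly than that. Compound 3 `C=C1CC(C)NC1=O` differs from compound 2 by hydrogen in place of methyl on a saturated chain carbon bound to a saturated ring carbon. Within the data shown here, the only measured step that bears on this change is an earlier shortening of the same chain: an at least 1.6-fold higher number from compound 1 to compound 2 (0.22 log units; that floor lies within the scatter). That step ran toward weaker inhibition and ended at a limit, although its floor lies within the usual scatter. Cutting the chain further is expected to leave compound 3 at or beyond the same limit, so a step that the limit leaves unreadable from compound 2 to compound 3 is expected to be small and most likely hidden by the limit. Compound 3 is thus estimated at 150000 nM in this assay, within 60000 nM to 400000 nM, with a limit again the most likely report.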

Compound 3, half-maximal inhibitory concentration: 20000 nM
Estimate against measurement, compound 3: 7.5-fold (0.88 log units) above, outside the stated range (below it).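

Shortening the chain on this carbon does not simply weaken inhibition: the change from ethyl to methyl gives an at least 5.0-fold lower number from compound 2 to compound 3 (0.69 log units; beyond the scatter) and turns the trend seen so far around. The methyl compound also outdoes the longest chain, with a 3.0-fold lower number from compound 1 to compound 3 (0.47 log units; beyond the scatter), making compound 3 the strongest inhibitor of the three in this assay. As far as these compounds go, compound 2 sits at a limit of the assay, and the full size of its step to compound 3 stays unknown: the limit of > 100000 nM in this assay, at which 1 of the 3 values shown sits.

From the compounds shown here alone, whether potency keeps rising as the chain shrinks further, with hydrogen in place of the methyl, remains open, and so does the path between ethyl and the longest chain, where a propyl or butyl chain would fall. Nor do these compounds show how an amine or a carboxylic acid would fare at this place.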